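Extending the ortho substituent from methyl to propyl

A few compounds are considered here, and "the series" means these few. Any claim that something is new, unique, unknown or untested is made for them only; others in the source may bear on it.

Of the compounds shown here, two of a shared core have numbers so far. Compound 1 `Cc1ccccc1NS(=O)(=O)c1cccc(NC(=O)NCCCCl)c1` gives 52000 nM in a functional assay on MCF7 cells (Homo sapiens) for cytotoxicity, read by sulforhodamine B assay, with a stated time of 48 h (on this read-out lower numbers stand for stronger inhibition and higher numbers for weaker inhibition), and compound 2 `CCNC(=O)Nc1cccc(S(=O)(=O)Nc2ccccc2C)c1` gives 108000 nM in this assay. For the measured compounds named here, the single counted step, a 2.1-fold higher number from compound 1 to compound 2 (0.32 log units; beyond the scatter), is the only one on record. Compound 2 thus holds the highest of the two numbers, and compound 1 sits nearest, with a lower number. Compound 3 `CCCc1ccccc1NS(=O)(=O)c1cccc(NC(=O)NCC)c1` differs from compound 2 by ethyl in place of hydrogen on a saturated chain carbon bound to an aromatic carbon; read one bond further out, this is methyl to propyl. Going by the values given here, no measured step touches this position: the one known step concerns the opposite end of the molecule, so the data give no direct guide. Compound 3 is therefore expected to stay close to compound 2, with an estimated step of a 1.4-fold lower number from compound 2 to compound 3 (0.13 log units; within the scatter) that may not pass beyond the scatter. The estimate for compound 3 in this assay is 80000 nM, within a range from 30000 nM to 250000 nM.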

Compound 3, half-maximal inhibitory concentration: 40000 nM
For compound 3 the middle estimate is 2.0-fold (0.30 log units) above the measured one; the measured number falls inside the stated range.
By their numbers in this assay, from the lowest: compounds 3 and 1 (each within the scatter of the next); then compound 2.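

In this assay, methyl to propyl on the saturated chain carbon bound to an aromatic carbon comes with a 2.7-fold lower number from compound 2 to compound 3 (0.43 log units; beyond the scatter). For the compounds shown here, this is the first measured step at this position, and it shows that the number responds to a change here as well as to the change in the chloromethyl group seen earlier. The step is modest but beyond the scatter, and it runs toward stronger inhibition. No measurement at hand accounts for the lower number with propyl.

On these data alone, whether a longer chain such as butyl or pentyl would lower the number further remains open, as does the effect of an amine or a carboxylic acid at the end of this chain. As far as these compounds go, it is also open whether propyl combined with the chloromethyl group of compound 1 would lower the number further.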